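Hydrazone aryl swap: dimethoxyphenyl to difluorophenyl, cytotoxicity expectation

The source may report more compounds than this note shows. Statements on the series, on what has been measured and on what is new or still open speak of the compounds shown alone.

Measured so far:
- compound 1 `CN(C)CCn1cnnc1-c1cc(Oc2ccc(NC(=O)N/N=C/c3c[nH]c4ccccc34)cc2F)ccn1`: 690 nM
- compound 2 `COc1ccc(/C=N/NC(=O)Nc2ccc(Oc3ccnc(-c4nncn4CCN(C)C)c3)c(F)c2)c(OC)c1`: 12600 nM

In a functional assay on U-87MG ATCC cells (Homo sapiens) for cytotoxicity, read by MTT assay, with a stated time of 72 h (on this read-out higher numbers stand for weaker inhibition and lower numbers for stronger inhibition), compound 2 holds the highest of the two numbers; its nearest neighbour is compound 1, separated by the step of an 18-fold higher number from compound 1 to compound 2 (1.26 log units; beyond the scatter), a large one. Compound 3 `CN(C)CCn1cnnc1-c1cc(Oc2ccc(NC(=O)N/N=C/c3ccc(F)cc3F)cc2F)ccn1` differs from compound 2 by 2,4-difluorophenyl in place of 2,4-dimethoxyphenyl on a carbon with a double bond to nitrogen. Going by the values given here, no measured step shares this exact change; only an 18-fold higher number from compound 1 to compound 2 (1.26 log units; beyond the scatter) shows that the aryl group on the hydrazone carbon can shift the number by a large margin, so a sizeable move in either direction is possible. On balance compound 3 is expected to sit near 5000 nM, within 1000 nM to 25000 nM, which means an expected step of a 2.5-fold lower number from compound 2 to compound 3 (0.40 log units; beyond the scatter).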

Compound 3, half-maximal inhibitory concentration: 1900 nM
Compound 3: the middle estimate sits 2.6-fold (0.42 log units) above what was measured; measured number inside the range.
By their numbers in this assay, from the lowest: compound 1; then compound 3; then compound 2.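

In this assay the outcome at this position depends on the groups carried by the phenyl ring, not only on the loss of 1H-indol-3-yl: 2,4-difluorophenyl in place of 2,4-dimethoxyphenyl gives a 6.6-fold lower number from compound 2 to compound 3 (0.82 log units; beyond the scatter). Even so, 2,4-difluorophenyl does not match 1H-indol-3-yl, with a 2.8-fold higher number from compound 1 to compound 3 (0.44 log units; beyond the scatter). No evidence bears on the reason for either step. Open, on these data alone, is whether unsubstituted phenyl or 2,4-dichlorophenyl would fall nearer compound 3. Also open, as far as these compounds go, is how another nitrogen-containing ring, such as pyridine, would compare with 1H-indol-3-yl.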